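This account rests on a few compounds, and the source may have more. Where it says the series, first, only, none or still open, it means among the compounds named here.

Compounds measured in a functional assay on CHO cells for agonist activity at prostaglandin E2 receptor EP2 subtype (Homo sapiens), read by HTRF and cAMP accumulation, with a stated time of 30 min (on this read-out higher numbers stand for an effect only at larger amounts of compound and lower numbers for an effect already at smaller amounts), so far:

- compound 1 `O=C(O)c1csc([C@H]2CC[C@@H]3[C@@H](COc4ccc(C(F)(F)F)cc4)[C@H](O)C[C@@H]3O2)n1`: compound 1 gives 13 nM
- compound 2 `O=C(O)c1csc([C@H]2CC[C@@H]3[C@@H](/C=C/[C@@H](O)COc4ccccc4)[C@H](O)C[C@@H]3O2)n1`: compound 2 gives 7.9 nM
- compound 3 `O=C(O)c1csc([C@H]2CC[C@@H]3[C@@H](COc4ccccc4F)[C@H](O)C[C@@H]3O2)n1`: compound 3 gives 23 nM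

On these numbers compound 3 has the highest value of the three. Its nearest neighbour is compound 1, whose value lies within the scatter of compound 3; the value of compound 2 lies beyond the scatter, on the lower side.

The next compound, compound 4 `O=C(O)c1csc([C@H]2CC[C@@H]3[C@@H](COc4ccc(F)cc4)[C@H](O)C[C@@H]3O2)n1`, has not yet been measured in this assay. It differs from compound 3 in one place: 4-fluorophenyl in place of 2-fluorophenyl on an oxygen on a saturated carbon. Going by the values given here, the only measured step that touches the same aromatic ring is a 1.8-fold higher number from compound 1 to compound 3 (0.25 log units; within the scatter); that step moved the fluorine-bearing ring in from a different direction but stayed inside the scatter. Nothing else among the measured compounds separates the two fluorophenyl arrangements from each other, so the step from compound 3 to compound 4 is expected to be small and, in all likelihood, not beyond the scatter in either direction: the expected step is a 1.5-fold lower number from compound 3 to compound 4 (0.19 log units; within the scatter). Compound 4 is therefore estimated at 15 nM in this assay, with a range from 6 nM to 40 nM.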

Compound 4, half-maximal effective concentration: 7 nM
Compound 4: middle estimate off by 2.1-fold (0.33 log units), on the high side; low and high end bracket the measured number.
By their numbers in this assay, from the lowest: compounds 4, 2, 1 and 3 (each within the scatter of the next, the first and the last beyond it).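

In this assay, going by these compounds alone, the place of the fluorine on the aromatic ring matters: 4-fluorophenyl in place of 2-fluorophenyl on an oxygen on a saturated carbon gives a 3.3-fold lower number from compound 3 to compound 4 (0.52 log units; beyond the scatter), the only single-place step so far that lies beyond the scatter, and it comes with the same atoms joined differently. Fluoro in place of trifluoromethyl on an aromatic carbon gives a 1.9-fold lower number from compound 1 to compound 4 (0.27 log units; within the scatter), so compound 1 and compound 4 do not separate on this read-out, while compound 3 and compound 4 do. No measurement is available here that explains the effect of moving the fluorine.

The compounds shown leave open how an unsubstituted phenyl, a chlorophenyl or a methoxyphenyl would compare with 4-fluorophenyl on the same short chain. They also leave open whether 4-fluorophenyl in place of the plain phenyl on the longer hydroxyl-bearing chain of compound 2 would give a step of similar direction and size.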